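This account rests on a few compounds, and the source may have more. Where it says the series, first, only, none or still open, it means among the compounds named here.

Of the compounds shown here, three built on one shared core have been measured in an assay on LtK cells with ATP-sensitive inward rectifier potassium channel 11 (Homo sapiens) as the target; a lower number here means that less compound is needed, a higher number that more compound is needed for the effect. Compound 1 `CC(C)C(=O)Nc1c(C(O)(C(F)(F)F)C(F)(F)F)ccc2ccccc12` carries an isopropyl group on its carbonyl carbon, and in this assay compound 1 gives 6630 nM. Compound 2 `CCCC(C)C(=O)Nc1c(C(O)(C(F)(F)F)C(F)(F)F)ccc2ccccc12` is reported in this assay only as a limit of the assay, > 10000 nM, not as a number (the limit of > 10000 nM in this assay, at which 1 of the 3 values shown sits). Compound 3 `O=C(NCCCCCCCl)Nc1c(C(O)(C(F)(F)F)C(F)(F)F)ccc2ccccc12` carries a (6-chlorohexyl)amino group on the carbonyl carbon, and in this assay compound 3 gives 4840 nM, the lower of the two actual numbers, although the step of a 1.4-fold lower number from compound 1 to compound 3 (0.14 log units; within the scatter) is too small to rank the two. The step of an at least 1.5-fold higher number from compound 1 to compound 2 (0.17 log units; that floor lies within the scatter) sits at the limit, while the step of an at least 2.0-fold lower number from compound 2 to compound 3 (0.31 log units; beyond the scatter) is the one clear movement in this set.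

Compound 4 `Cc1cccc(C(=O)Nc2c(C(O)(C(F)(F)F)C(F)(F)F)ccc3ccccc23)c1` has not yet been measured. It differs from compound 3 in one place: 3-methylphenyl in place of (6-chlorohexyl)amino on a carbonyl carbon. Among the measured compounds shown here, no measured step exchanges a chain for an aromatic ring on this carbonyl carbon, so the direction of the change is open. The steps of a 1.4-fold lower number from compound 1 to compound 3 (0.14 log units; within the scatter) and an at least 2.0-fold lower number from compound 2 to compound 3 (0.31 log units; beyond the scatter) show that exchanges at this position have moved the number only modestly, so the step of a 1.0-fold higher number from compound 3 to compound 4 (0.01 log units; within the scatter) is expected to be of similar modest size. Compound 4 is therefore estimated at 5000 nM, with a range from 1500 nM to 15000 nM.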

Compound 4, half-maximal effective concentration: 23 nM
The estimate for compound 4 lay 220-fold (2.34 log units) above the measured number; the whole stated range lies above it.
By their numbers in this assay, from the lowest: compound 4; then compounds 3 and 1 (each within the scatter of the next). At a limit, above all of these: compound 2.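

Among the earlier compounds, the open groups on this carbonyl carbon stayed close together, and only the limit of compound 2 hinted at any movement. Placing 3-methylphenyl on the same carbon gives a 210-fold lower number from compound 3 to compound 4 (2.32 log units; beyond the scatter) and a 290-fold lower number from compound 1 to compound 4 (2.46 log units; beyond the scatter) in this assay and so shows that this position can shift the number far more than those exchanges suggested. Compound 2 is held only as a limit and not as a number, and its step is an at least 430-fold lower number from compound 2 to compound 4 (2.63 log units; beyond the scatter) and is therefore a floor, which leaves all three open groups, isopropyl, 1-methylbutyl and (6-chlorohexyl)amino, well above the one aromatic ring shown.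

Among the compounds shown here, with only one aromatic group in hand, it stays open whether the ring alone carries this change or whether its methyl group matters too, a question that a plain phenyl group or a pyridine ring on the same carbon would help to settle. Nothing in the data shown explains why this exchange has such a large effect.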